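The source may report more compounds than this note shows. Statements on the series, on what has been measured and on what is new or still open speak of the compounds shown alone.

Compound 1 `CN(Cc1ccc2nccn2c1)c1nnc(-c2ccccc2)o1` gives only a limit in an assay on isolated protein for inhibition of tyrosine-protein kinase receptor UFO (Homo sapiens), read by LC-MS (on this read-out higher numbers stand for weaker inhibition and lower numbers for stronger inhibition), at > 100000 nM. Compound 2 `CN(Cc1ccc2nccn2c1)c1nnc(-c2ccc(-c3ccccc3C#N)cc2)o1` gives the only number shown, 3980 nM. The measured step of an at least 25-fold lower number from compound 1 to compound 2 (1.40 log units; beyond the scatter) is large, and the limit of > 100000 nM in this assay, at which 1 of the 2 values shown sits, allows it to be larger still. Compound 3 `Cc1ncccc1-c1ccc(-c2nnc(N(C)Cc3ccc4nccn4c3)o2)cc1` differs from compound 2 in one place: 2-methylpyridin-3-yl in place of 2-cyanophenyl on an aromatic carbon. For the measured compounds named here, no measured step exchanges one aromatic group for another here; the only step that bears on it put 2-cyanophenyl in place of hydrogen and was large. Since both groups are one six-membered aromatic ring with one hydrogen-bond acceptor, a step within the scatter is expected, a 1.0-fold higher number from compound 2 to compound 3 (0.00 log units; within the scatter). Compound 3 is estimated at 4000 nM, between 1000 nM and 16000 nM.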

Compound 3, half-maximal inhibitory concentration: 6310 nM
Compound 3: the middle estimate sits 1.6-fold (0.20 log units) below what was measured; measured number inside the range.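

The exchange gives a 1.6-fold higher number from compound 2 to compound 3 (0.20 log units; within the scatter) in this assay, so at this place, para to a large group, a six-membered aromatic ring with 1 hetero atom and no nitrile serves as well as the carbon-only ring with its nitrile. Against hydrogen, 2-methylpyridin-3-yl gives an at least 15-fold lower number from compound 1 to compound 3 (1.19 log units; beyond the scatter), a second large step, and this one also starts from a limit: the limit of > 100000 nM in this assay, at which 1 of the 3 values shown sits.

Whether an aromatic ring is needed here stays open, as a morpholine, an amine or a carboxylic acid at this place is not among the compounds shown. Also open, as far as these compounds go, is what the methyl and the ring nitrogen of 2-methylpyridin-3-yl each contribute.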